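Alanine to glycine in a weak cytotoxic series

The compounds below may be only part of what the source reports. "The series", "measured", "known", "first", "only" and "open" are said of these compounds alone.

Measured compounds:
compound 1 `CC(C)=CCC/C(C)=C/CC/C(C)=C/CSc1ccccc1C(=O)N1CCC[C@H]1C(=O)OC(C)CCOc1no[n+]([O-])c1S(=O)(=O)c1ccccc1`: 13900 nM
compound 2 `CC(C)=CCC/C(C)=C/CC/C(C)=C/CSc1ccccc1C(=O)N[C@@H](C)C(=O)OC(C)CCOc1no[n+]([O-])c1S(=O)(=O)c1ccccc1`: > 50000 nM
compound 3 `CC(C)=CCC/C(C)=C/CC/C(C)=C/CSc1ccccc1C(=O)N[C@@H](C)C(=O)OCCCCOc1no[n+]([O-])c1S(=O)(=O)c1ccccc1`: 44600 nM

In a functional assay on SGC-7901 cells (Homo sapiens) for cytotoxicity, read by MTT assay, with a stated time of 48 h (a lower number here means a stronger inhibitor, a higher number a weaker inhibitor), compound 3 gives the highest of the two numbers, and compound 1 gives the lower one; that gap lies beyond the scatter. For compound 2 the value is a limit of this assay, not a number, as the limit of > 50000 nM in this assay, at which 1 of the 3 values shown sits, states. Compound 4 `CC(C)=CCC/C(C)=C/CC/C(C)=C/CSc1ccccc1C(=O)NCC(=O)OCCCCOc1no[n+]([O-])c1S(=O)(=O)c1ccccc1` is not yet measured; it differs from compound 3 by hydrogen in place of methyl on a saturated chain carbon bound to an amide-type nitrogen and a carbonyl carbon. For the measured compounds named here, no measured step shows this change, so no size can be read off. Compound 4 is expected to stay close to compound 3, with a step of a 1.0-fold higher number from compound 3 to compound 4 (0.00 log units; within the scatter) in this assay, which is within the scatter. Compound 4 is therefore estimated at 45000 nM, between 18000 nM and 120000 nM.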

Compound 4, half-maximal inhibitory concentration: > 50000 nM
Compound 4: only a limit was reported; the forecaster's own chance of this, stated with the estimate: 35%; middle value at least 1.1-fold (0.04 log units) from the limit.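

In this assay compound 4 gives > 50000 nM, a limit and not a number, and compound 2 sits at the same limit: the limit of > 50000 nM in this assay, at which 2 of the 4 values shown sit. Hydrogen in place of methyl on this saturated chain carbon gives an at least 1.1-fold higher number from compound 3 to compound 4 (0.04 log units; that floor lies within the scatter). For the compounds shown here, this is the first direct look at this position, and it shows that removing the methyl brings no measurable gain in strength, although the size of any loss cannot be read.

From the compounds shown here alone, it remains open how far compound 4 lies past the limit. The compounds shown also leave open whether an ethyl or a hydroxymethyl group on this carbon would give a stronger number.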